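A few compounds are considered here, and "the series" means these few. Any claim that something is new, unique, unknown or untested is made for them only; others in the source may bear on it.

Compound 1, `COc1ccc(Cc2nnc(NC(=O)/C(C#N)=C/c3ccccc3OS(=O)(=O)c3ccccc3[N+](=O)[O-])s2)cc1`, is a phenylacrylamide carrying a (2-nitrophenyl)sulfonyl group on the oxygen of the benzylidene ring and a 4-methoxybenzyl group on the thiadiazole. In an ADME assay on HEK-293T cells (Homo sapiens) for inhibition, read by CCK-8 assay, with a stated time of 48 h, tested at 20 uM (a higher number here means more inhibition of growth at the concentration tested, a lower number less inhibition of growth), compound 1 gives 18%. Compound 2, `COc1ccc(Cc2nnc(NC(=O)/C(C#N)=C/c3ccccc3OS(=O)(=O)c3ccc(F)cc3)s2)cc1`, keeps everything except the sulfonyl aryl group, where the change is 4-fluorophenyl in place of 2-nitrophenyl on a sulfonyl sulfur. In this assay compound 2 gives 6%, and the step is a number 12 percentage points lower from compound 1 to compound 2 (beyond the scatter).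

Compound 3, `N#C/C(=C\c1ccccc1OS(=O)(=O)c1ccccc1[N+](=O)[O-])C(=O)Nc1nnc(Cc2cccc(F)c2)s1`, shares the (2-nitrophenyl)sulfonyl group of compound 1 but differs in the core, the difference being (3-fluorophenyl in place of 4-methoxyphenyl on a saturated chain carbon bound to an aromatic carbon). In this assay compound 3 gives "not toxic" (no number reported), so no single number is available for it. Compound 4, `N#C/C(=C\c1ccccc1OS(=O)(=O)c1ccc(F)cc1)C(=O)Nc1nnc(Cc2cccc(F)c2)s1`, is related to compound 3 by 4-fluorophenyl in place of 2-nitrophenyl on a sulfonyl sulfur. This is the same change as that from compound 1 to compound 2, made at the same place: the sulfonyl sulfur whose other neighbour is an oxygen on an aromatic ring.

For compound 4 in this assay a modest downward step, of the size seen from compound 1 to compound 2, is expected, because compound 1 already lies low and compound 2 is lower still with a number 12 percentage points lower from compound 1 to compound 2 (beyond the scatter). Since compound 3 is reported only as not toxic, the expected value for compound 4 is 5%, within a range from 0% to 15%.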

Compound 4, percent growth inhibition at one concentration: 17%
For compound 4 the middle estimate is 12 percentage points below the measured one; measured number above the stated range.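

In this assay, among the compounds shown here, the sulfonyl change cannot be followed from one core to the other: compound 3 gives "not toxic" (no number reported), so the step from it to compound 4 cannot be read, and the step seen in the core of compound 1, a number 12 percentage points lower from compound 1 to compound 2 (beyond the scatter), has no numerical counterpart, which means it is neither confirmed nor contradicted. What the new step does show is that, with the 4-fluorophenyl group held on the sulfonyl sulfur, 3-fluorophenyl in place of 4-methoxyphenyl on a saturated chain carbon bound to an aromatic carbon gives a number 11 percentage points higher from compound 2 to compound 4 (beyond the scatter), so the number for a given sulfonyl group is not the same in both cores, although this rests on a single pair of compounds. The data shown offer no measured explanation for this rise.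

The compounds shown leave open whether the same core change would move the number in the same way with the 2-nitrophenyl group on the sulfonyl sulfur. They also leave open how the number would respond to a carboxylic acid or a dimethylamino group on the sulfonyl aryl ring, or to a longer chain leading to the 3-fluorophenyl group.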